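The compounds below may be only part of what the source reports. "The series", "measured", "known", "first", "only" and "open" are said of these compounds alone.

Of the compounds shown here, three have been measured so far. In a functional assay on SNU-16 cells (Homo sapiens) for antiproliferative activity, read by CCK-8 assay, with a stated time of 72 h (on this read-out higher numbers stand for weaker inhibition and lower numbers for stronger inhibition), compound 1 `COc1cccc(-c2ccc3c(NC(=O)c4ccc(N5CCN(C)CC5)c(F)c4)n[nH]c3c2)c1F` gives only a limit, > 1000 nM. Compound 3 `CCN1CCN(c2ccc(C(=O)Nc3n[nH]c4cc(-c5cccc(OC)c5F)ccc34)cc2C(F)(F)F)CC1` likewise gives only a limit, > 1000 nM. Going by the values given here, compound 2 `COc1ccc(F)c(-c2ccc3c(NC(=O)c4ccc(N(C)CCN(C)C)cc4)n[nH]c3c2)c1F` gives 366 nM, the one real number among the three, while the other two sit at the limit of > 1000 nM in this assay, at which 2 of the 3 values shown sit.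

Compound 4 `CCN1CCN(c2ccc(C(=O)Nc3n[nH]c4cc(-c5c(F)ccc(OC)c5F)ccc34)cc2)CC1` has not yet been measured. It keeps the core and the aryl group of compound 2 and differs in one place: 4-ethylpiperazin-1-yl in place of (2-(dimethylamino)ethyl)(methyl)amino on an aromatic carbon. Among the compounds with values here, no measured pair shows the effect of this exchange on its own. Compound 1 and compound 3 both carry a ring amine where compound 2 carries the open chain, and both sit at the limit of > 1000 nM in this assay, at which 2 of the 3 values shown sit, so a modest weakening is expected, though each also differs elsewhere from compound 2 and the step may fall within the scatter. Compound 4 is therefore expected near 600 nM, between 150 nM and 2500 nM, a step of a 1.6-fold higher number from compound 2 to compound 4 (0.21 log units; within the scatter).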

Compound 4, half-maximal inhibitory concentration: 77.4 nM
Compound 4: middle estimate off by 7.8-fold (0.89 log units), on the high side, outside the stated range (below it).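

In this assay, this aromatic carbon, para to a large group, tolerates a ring amine and gains from it: replacing the open (2-(dimethylamino)ethyl)(methyl)amino chain with 4-ethylpiperazin-1-yl gives a stronger result (a 4.7-fold lower number from compound 2 to compound 4 (0.67 log units; beyond the scatter)). Going by these compounds alone, this is the only step here that isolates the exchange, and it shows that the group at this place alone can move the value beyond the scatter.

Going by these compounds, whether the ring or its ethyl group matters stays open, and a morpholine or an unsubstituted piperazine at this place would separate the two. Nothing measured here gives a reason for the step.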